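Nitro for chloro on the benzyl arm: cytotoxicity outlook

The source may report more compounds than this note shows. Statements on the series, on what has been measured and on what is new or still open speak of the compounds shown alone.

Measured so far:
Compound 1 `Cc1cc(C)c(Oc2cc(Nc3ccc(C#N)cc3)ncc2C(=O)NCc2cn(Cc3ccccc3Cl)nn2)c(C)c1`: in an ADME assay on MT4 cells (Homo sapiens) for cytotoxicity, read by MTT assay, with a stated time of 5 days (on this read-out lower numbers stand for higher toxicity in this test and higher numbers for lower toxicity in this test), compound 1 gives >= 188000 nM, which is a limit of the assay, not a number.
Compound 2 `Cc1cc(C)c(Oc2cc(Nc3ccc(C#N)cc3)ncc2C(=O)NCc2cn(Cc3cccc(Cl)c3)nn2)c(C)c1`: in this assay compound 2 gives 187000 nM.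
Compound 3 `Cc1cc(C)c(Oc2cc(Nc3ccc(C#N)cc3)ncc2C(=O)NCc2cn(Cc3ccc(F)cc3)nn2)c(C)c1`: in this assay compound 3 gives >= 153000 nM, which is a limit of the assay, not a number.

Within the data shown here, compound 2 stands as the only real number in this set; the other two values are limits. Compound 4 `Cc1cc(C)c(Oc2cc(Nc3ccc(C#N)cc3)ncc2C(=O)NCc2cn(Cc3cccc([N+](=O)[O-])c3)nn2)c(C)c1` differs from compound 2 in one place: nitro in place of chloro on an aromatic carbon, that is, 3-chlorobenzyl to 3-nitrobenzyl.

Among the measured compounds shown here, three measured steps touch the same benzyl position: a number no higher from compound 1 to compound 2 (the limit leaves the size open), a step that the two limits leave unreadable from compound 1 to compound 3 and a step that the limit leaves unreadable from compound 2 to compound 3. None of them can be sized, as one value sits at the limit of >= 188000 nM in this assay, at which 1 of the 3 values shown sits, and one at the limit of >= 153000 nM in this assay, at which 1 of the 3 values shown sits. What is readable points to no step beyond the scatter among the three benzyl variants, and the expected step to compound 4 is therefore a 1.0-fold lower number from compound 2 to compound 4 (0.00 log units; within the scatter). Compound 4 is expected to give about 185000 nM, within 100000 nM to 350000 nM, and it may well come back as a limit rather than a number.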

Compound 4, half-maximal cytotoxic concentration: >= 156000 nM
Compound 4: a limit, no number; the forecaster's own chance of this, stated with the estimate: 60%; the middle value does not contradict the limit.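

Compound 4 comes back as a limit of the assay, not a number, and none of its steps to compound 1, compound 2 or compound 3 in this assay can be read. The compounds shown leave open whether any change on the benzyl arm moves this read-out beyond the usual scatter.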